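Replacing 3-methylfuran-2-yl with oxolan-3-yl on a carbonyl carbon

This account rests on a few compounds, and the source may have more. Where it says the series, first, only, none or still open, it means among the compounds named here.

Compound 1 `Cc1occc1C(=O)N1CCC(NC(=O)Nc2ccc(OC(F)(F)F)cc2)CC1`: 4.3
Compound 2 `O=C(Nc1ccc(C(F)(F)F)c(F)c1)NC1CCN(C(=O)C2CC2)CC1`: 3.94
Compound 3 `Cc1ccoc1C(=O)N1CCC(NC(=O)Nc2ccc(C(F)(F)F)cc2)CC1`: 4.29

All three values come from a physicochemical assay for lipophilicity, read by HPLC, with a stated time of 90 min, tested at 100 uM; on this read-out higher numbers stand for higher lipophilicity and lower numbers for lower lipophilicity. Here compound 3 gives 4.29, level with compound 1 at 4.3, as the two lie within the usual scatter of each other. Compound 2, at 3.94, stands lower than compound 3, and that gap goes beyond the scatter. Among the measured compounds shown here, no two measured compounds differ in one place only, so the data offer no direct step to draw on.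

The next compound to be measured is compound 4 `O=C(Nc1ccc(C(F)(F)F)cc1)NC1CCN(C(=O)[C@@H]2CCOC2)CC1`. It differs from compound 3 at a single place, with oxolan-3-yl in place of 3-methylfuran-2-yl on a carbonyl carbon. A five-membered aromatic ring leaves and a five-membered non-aromatic ring enters.

In this assay a downward step beyond the scatter is expected. For the measured compounds named here, the only hint is compound 2, which has no five-membered aromatic ring and gives 3.94, although it also differs from compound 3 elsewhere. The expected change is a number 0.69 log units lower from compound 3 to compound 4 (beyond the scatter). For compound 4 the estimate is 3.6, with an expected range from 3.2 to 3.95.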

Compound 4, partition coefficient: 3.27
Compound 4: middle estimate off by 0.33 log units, on the high side; measured number inside the range.
By their numbers in this assay, from the lowest: compound 4; then compound 2; then compounds 3 and 1 (each within the scatter of the next).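

In this assay, among the compounds shown here, the swap of 3-methylfuran-2-yl for oxolan-3-yl on the carbonyl carbon gives a large step, a number 1.02 log units lower from compound 3 to compound 4 (beyond the scatter), and this is the first step that isolates a single place. The earlier compounds shown here could only hint at this position, since compound 2 differs from compound 3 in more than one place, whereas this pair shows directly that the group on this carbonyl carbon alone can move the read-out well beyond the scatter. No accompanying measurement explains the size of this step.

The one step removes the aromatic ring and the methyl group together, and it also brings in a defined stereocentre, so the compounds shown cannot divide the step among these differences. Going by these compounds, a furan-2-yl group without the methyl, a cyclopentyl group or the opposite stereoisomer of oxolan-3-yl on the same carbonyl carbon would bear on that division, and how far this step holds with other groups elsewhere on the core of compound 3 also remains open.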